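Silyl ether series: phenol swap at the double-bonded carbon

The source may hold more compounds than are shown below. What is called first, only, known or untested is meant among the compounds shown, and "the series" means these compounds.

Compound 1 `COc1ccc(C2=C(c3cc(OC)c(OC)c(OC)c3)C(=O)CC2O[SiH2]C(C)(C)C)cc1OC`: > 100 ug/mL
Compound 2 `COc1ccc(C2=C(c3cc(OC)c(OC)c(OC)c3)C(=O)CC2O)cc1O`: < 1 ug/mL
Compound 3 `COc1cc(C2=C(c3cc(C)c(OC)c(C)c3)C(O[SiH2]C(C)(C)C)CC2=O)cc(OC)c1OC`: 32 ug/mL

Within the data shown here, in an ADME assay on PA-1 cells (Homo sapiens) for cytotoxicity, read by MTT assay, with a stated time of 72 h (a lower number here means a stronger inhibitor, a higher number a weaker inhibitor), compound 3 gives 32 ug/mL, the only plain number in the set. The other two values are limits of the assay. Compound 1 sits at the upper limit of this assay, (the limit of > 100 ug/mL in this assay, at which 1 of the 3 values shown sits). Compound 2 sits at the lower limit, (the limit of < 1 ug/mL in this assay, at which 1 of the 3 values shown sits). Compound 4 `COc1ccc(C2=C(c3cc(OC)c(OC)c(OC)c3)C(=O)CC2O[SiH2]C(C)(C)C)cc1O` has not been measured; it differs from compound 3 as follows: 3-hydroxy-4-methoxyphenyl in place of 4-methoxy-3,5-dimethylphenyl on a double-bonded ring carbon. Among the measured compounds shown here, the single measured step, an at least 3.1-fold lower number from compound 1 to compound 3 (0.49 log units; beyond the scatter), concerns the same position but other groups, so it does not carry over directly. Compound 1 and compound 4 share the silyl ether, compound 2 and compound 4 share the phenol ring, and those two limits point in opposite directions with no step shown between them. For compound 4 the expected value in this assay is 40 ug/mL, with range 5 ug/mL to 100 ug/mL. The step of a 1.3-fold higher number from compound 3 to compound 4 (0.10 log units; within the scatter) is thus expected to remain within the scatter.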

Compound 4, half-maximal inhibitory concentration: 14 ug/mL
Estimate against measurement, compound 4: 2.9-fold (0.46 log units) above, and the stated range covers the measured number.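

In this assay, 3-hydroxy-4-methoxyphenyl in place of 4-methoxy-3,5-dimethylphenyl on the double-bonded ring carbon gives a 2.3-fold lower number from compound 3 to compound 4 (0.36 log units; beyond the scatter). With the silyl ether kept, hydrogen in place of methyl on the oxygen on the aromatic ring gives an at least 7.1-fold lower number from compound 1 to compound 4 (0.85 log units; beyond the scatter), and the start of that step is a limit of the assay: the limit of > 100 ug/mL in this assay, at which 1 of the 4 values shown sits. With the phenol ring kept, the silyl group on the oxygen on the saturated carbon gives an at least 14-fold higher number from compound 2 to compound 4 (1.14 log units; beyond the scatter), and the start of that step is also a limit: the limit of < 1 ug/mL in this assay, at which 1 of the 4 values shown sits. Still open, on these data alone, is whether an amine or a fluorine in place of the hydroxy group of the 3-hydroxy-4-methoxyphenyl would give a similar number.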